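Methyl on the aryl ring of a thiophene acrylamide

This account rests on a few compounds, and the source may have more. Where it says the series, first, only, none or still open, it means among the compounds named here.

Three compounds share an acrylamide chain attached to a five-membered aromatic ring that carries a phenyl-type group. Compound 1 is `C/C(=C\c1cc(-c2ccccc2)co1)C(N)=O`. In a functional assay on T-24 cells (Homo sapiens) for cytotoxicity, read by CCK-8 assay, with a stated time of 24 h (on this read-out higher numbers stand for weaker inhibition and lower numbers for stronger inhibition), compound 1 gives > 50000 nM, which is a limit of the assay and not a number. Compound 2 is `C/C(=C\c1ccc(-c2ccc(C)cc2)o1)C(N)=O`. In this assay compound 2 gives > 50000 nM, again a limit. Compound 3 is `C/C(=C\c1cc(-c2ccccc2)cs1)C(N)=O`. In this assay compound 3 gives > 50000 nM, also a limit, so for compound 3 only a boundary is known. This is the position shared by all three: the limit of > 50000 nM in this assay, at which 3 of the 3 values shown sit, and so none of them shows measurable inhibition within the tested range.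

Compound 4 is `C/C(=C\c1cc(-c2ccc(C)cc2)cs1)C(N)=O`. It differs from compound 3 by one change, methyl in place of hydrogen on an aromatic carbon, on an aromatic carbon of a six-membered aromatic ring of carbon only, para to a large group. Among the compounds with values here, no step between measured compounds is available, since all values are limits. The same kind of methyl is present in compound 2, whose value is > 50000 nM in this assay, also a limit. The step from compound 3 to compound 4 is therefore expected to be none beyond the scatter, a step that the limit leaves unreadable from compound 3 to compound 4. Compound 4 is estimated at 70000 nM, with a range from 30000 nM to 200000 nM, most likely reported again only as a limit.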

Compound 4, half-maximal inhibitory concentration: > 50000 nM
Compound 4 gave a limit, no number (the forecaster's own chance of this, stated with the estimate: 85%); the middle value lies beyond the limit too.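

Compound 3 and compound 4 both stand at a limit in this assay, so the change of hydrogen to methyl yields no readable step between them. All the compounds shown share the same boundary: the limit of > 50000 nM in this assay, at which 4 of the 4 values shown sit.

From the compounds shown here alone, whether the methyl alters inhibition at all, and whether any change to this series gives a measurable value, stays open.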